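Methanesulfonamido for methoxy on the shared core

This account rests on a few compounds, and the source may have more. Where it says the series, first, only, none or still open, it means among the compounds named here.

Measured so far:
compound 1 `Cc1n[nH]cc1-c1cccc2c1CCC2c1ncc[nH]1` — 902 nM
compound 2 `COc1c(C)ccc2c1CCC2c1ncc[nH]1` — > 10000 nM (a limit of the assay)

In a functional assay on CHO cells for agonist activity at Alpha-1B adrenergic receptor (Homo sapiens), read by FLIPR and calcium flux (a lower number here means that less compound is needed, a higher number that more compound is needed for the effect), compound 1 gives 902 nM. For compound 2 the assay returns no number; compound 2 sits at the limit of > 10000 nM in this assay, at which 1 of the 2 values shown sits. Compound 2 therefore stands at the inactive end of the two values shown, with its true potency unresolved.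

Compound 3 `Cc1ccc2c(c1NS(C)(=O)=O)CCC2c1ncc[nH]1` differs from compound 2 by methanesulfonamido in place of methoxy on an aromatic carbon. For the measured compounds named here, no measured pair in the set shows this exchange, so its size has to be expected rather than read off. Compound 1, carrying a larger group at the same place on the core, is active at 902 nM, which suggests that substituents bigger than methoxy there are tolerated. The step from compound 2 to compound 3 is expected to run toward lower values, an at least 4.0-fold lower number from compound 2 to compound 3 (0.60 log units; beyond the scatter), beyond the scatter. Compound 3 is estimated at 2500 nM, within 500 nM to 10000 nM.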

Compound 3, half-maximal effective concentration: > 10000 nM
Compound 3 gave a limit, no number (the forecaster's own chance of this, stated with the estimate: 30%); middle value at least 4.0-fold (0.60 log units) from the limit.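

Compound 2 and compound 3 both stop at the same limit, so no step between them can be read: the limit of > 10000 nM in this assay, at which 2 of the 3 values shown sit.

As far as these compounds go, whether methanesulfonamido in place of methoxy on an aromatic carbon changes potency at all stays open, as does the true potency of either compound.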